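Adding a chloro group to compound 3

The source may hold more compounds than are shown below. What is called first, only, known or untested is meant among the compounds shown, and "the series" means these compounds.

Compound 1 `COc1ccc(N(C)c2ccnc(Cl)n2)cc1OCCBr` gives 6620 nM
Compound 2 `COc1ccc(N(C)c2ccnc(Cl)n2)cc1OCC[Se]C#N` gives 2750 nM
Compound 3 `COc1ccc(N(C)c2cc(C)nc(C)n2)cc1` gives 3650 nM
Compound 4 `COc1ccc(N(C)c2cc(C)nc(C)n2)cc1Cl` has not yet been measured

All three values come from a functional assay on MDA-MB-231 cells (Homo sapiens) for antiproliferative activity, read by MTT assay, with a stated time of 48 h (on this read-out lower numbers stand for stronger inhibition and higher numbers for weaker inhibition), and compound 3 lies within the usual scatter of both compound 1 and compound 2. Compound 4 differs from compound 3 by a single change: chloro in place of hydrogen on an aromatic carbon. Among the compounds with values here, the only measured step, a 2.4-fold lower number from compound 1 to compound 2 (0.38 log units; beyond the scatter), is a swap on a saturated chain carbon, so it gives a sense of scale but no direct evidence about chloro. In this assay the expected step is a 1.2-fold lower number from compound 3 to compound 4 (0.09 log units; within the scatter), which means no change beyond the scatter is expected. For compound 4 the estimate is 3000 nM, with an expected range from 1000 nM to 8000 nM.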

Compound 4, half-maximal inhibitory concentration: 1900 nM
The estimate for compound 4 lay 1.6-fold (0.20 log units) above the measured number; the range from low to high includes it.
By their numbers in this assay, from the lowest: compounds 4, 2, 3 and 1 (each within the scatter of the next, the first and the last beyond it).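

In this assay, within the data shown here, putting chloro in place of hydrogen on an aromatic carbon, ortho to a methoxy group, gives a 1.9-fold lower number from compound 3 to compound 4 (0.28 log units; within the scatter), so this is the first direct reading at this position, and a single chlorine atom here causes no change beyond the scatter. No measurement shown explains the size of this step. Going by these compounds, whether a different group at this position, such as fluoro, methyl or an amine, would move the number beyond the scatter remains open. So does whether a longer chain there would do so.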